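The source may hold more compounds than are shown below. What is called first, only, known or untested is meant among the compounds shown, and "the series" means these compounds.

Measured so far:
compound 1 `CC(C)n1cnc2c(Nc3ccccc3)nc(NCOCc3ccc(C(=O)Nc4ccccc4N)cc3)nc21`, 15%;
compound 2 `Nc1ccccc1NC(=O)c1ccc(COCNc2nc(Nc3ccccc3)c3ncn(C4CCCC4)c3n2)cc1`, 41.2%;
compound 3 `CCCCn1cnc2c(Nc3ccccc3)nc(NCOCc3ccc(/C=C/C(=O)Nc4ccccc4N)cc3)nc21`, 23.1%.

All three were tested in a functional assay on NCI-H460 cells (Homo sapiens) for antiproliferative activity, read by CCK-8 assay, with a stated time of 72 h, tested at 2 uM; a higher number here means a stronger effect of the compound at the concentration tested, a lower number a weaker effect. Compound 3 stands second highest of the three numbers: its value sits within the scatter of compound 1, and compound 2 lies above it by an amount beyond the scatter. Within the data shown here, the only step measured between compounds that differ in one place is a number 26.2 percentage points higher from compound 1 to compound 2 (beyond the scatter), and that step concerns the group on an aromatic nitrogen, not the part altered here. Compound 4 `CCCCn1cnc2c(Nc3ccccc3)nc(NCOCc3ccc(C(=O)Nc4ccccc4N)cc3)nc21` differs from compound 3 by (2-aminophenyl)carbamoyl in place of 2-((2-aminophenyl)carbamoyl)ethenyl on an aromatic carbon. Among the measured compounds shown here, no measured step bears directly on this change. Compound 1 and compound 3 differ both in the group on the aromatic nitrogen and in this linker; compound 1 gives 15%, and compound 3 gives 23.1%, values within the scatter of each other. A step of no clear size beyond the scatter is therefore expected, and compound 4 is estimated at 18%, within 5% to 35%, which means an expected step of a number 5.1 percentage points lower from compound 3 to compound 4 (within the scatter).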

Compound 4, a percentage reported as inhibition, at one concentration (the size of the read-out at that concentration, not a potency): 27.7%
Compound 4: the middle estimate sits 9.7 percentage points below what was measured; the range from low to high includes it.
By their numbers in this assay, from the lowest: compounds 1, 3 and 4 (each within the scatter of the next, the first and the last beyond it); then compound 2.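

In this assay, the first direct test of this position, (2-aminophenyl)carbamoyl in place of 2-((2-aminophenyl)carbamoyl)ethenyl gives a number 4.6 percentage points higher from compound 3 to compound 4 (within the scatter), so with butyl on the aromatic nitrogen, the ethenyl piece makes no readable difference. With (2-aminophenyl)carbamoyl held fixed, the group on the aromatic nitrogen does matter: butyl in place of isopropyl gives a number 12.7 percentage points higher from compound 1 to compound 4 (beyond the scatter), and butyl in place of cyclopentyl gives a number 13.5 percentage points lower from compound 2 to compound 4 (beyond the scatter), placing butyl between the other two groups. No supporting measurement explains either result.

As far as these compounds go, it remains open whether the ethenyl piece would also make no readable difference with cyclopentyl on the nitrogen. It is also unknown how a cyclohexyl group or a longer chain such as hexyl on that nitrogen, or a hydroxamic acid in place of the (2-aminophenyl)carbamoyl group, would read.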